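Notes on acetyl removal in a small ester series

The compounds below may be only part of what the source reports. "The series", "measured", "known", "first", "only" and "open" are said of these compounds alone.

Of the compounds shown here, two carry numbers so far. Compound 1 `COc1ccc(C(=O)O[C@H]2CC(C)=C[C@H](O)[C@@]3(C)[C@@H](OC(C)=O)C[C@@](O)(C(C)C)[C@H]23)cc1` gives 18100 nM in a functional assay on SEM cells (Homo sapiens) for cytotoxicity, read by MTT assay, with a stated time of 72 h; on this read-out lower numbers stand for stronger inhibition and higher numbers for weaker inhibition. Compound 2 `COc1ccc(C(=O)O[C@H]2CC(C)=C[C@@H](OC(C)=O)[C@@]3(C)[C@@H](OC(C)=O)C[C@@](O)(C(C)C)[C@H]23)cc1` gives 32900 nM in the same read-out, the higher of the two numbers, with compound 1 as its nearest neighbour at a gap that lies within the scatter of repeated measurements; no order between the two is claimed. Compound 3 `COc1ccc(C(=O)O[C@H]2CC(C)=C[C@@H](O)[C@@]3(C)[C@@H](OC(C)=O)C[C@@](O)(C(C)C)[C@H]23)cc1` has not yet been measured. It differs from compound 2 in one place: hydrogen in place of acetyl on an oxygen on a saturated carbon. No step between measured compounds in the series matches this change, so the expectation for compound 3 rests on the two numbers shown. The step of a 1.3-fold lower number from compound 2 to compound 3 (0.12 log units; within the scatter) is expected to be small and toward a lower number, not beyond the scatter. Compound 3 is estimated at 25000 nM, with a range from 10000 nM to 60000 nM.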

Compound 3, half-maximal inhibitory concentration: > 100000 nM
Compound 3 gave a limit, no number (the forecaster's own chance of this, stated with the estimate: 10%); middle value at least 4.0-fold (0.60 log units) from the limit.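

Compound 3 in this assay is a limit of the assay, not a number: the limit of > 100000 nM in this assay, at which 1 of the 3 values shown sits.

Going from acetoxy to hydroxy at this position gives an at least 3.0-fold higher number from compound 2 to compound 3 (0.48 log units; beyond the scatter), so in the configuration drawn in compound 2 the acetyl cannot be removed without weaker inhibition, which the earlier two values could not show. Changing a stereocentre at a saturated ring carbon with atoms and bonds unchanged gives an at least 5.5-fold higher number from compound 1 to compound 3 (0.74 log units; beyond the scatter), so the hydroxy group alone does not set the read-out and its drawn configuration counts as well: the fact that compounds 1 and 3 differ only in the configuration as drawn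

On these data alone, only one configuration of the acetoxy compound appears, so it stays open whether the acetyl step depends on configuration. As far as these compounds go, it also stays open how an amine, a carboxylic acid or a longer acyl chain on this oxygen would read.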